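The source may hold more compounds than are shown below. What is called first, only, known or untested is meant among the compounds shown, and "the series" means these compounds.

Measured so far:

Compound 1, `Cc1ccc(Nc2cc(NC(=O)Nc3c(Cl)cccc3Cl)ncn2)cc1F`, gives 92% in a functional assay on PC-9 cells (Homo sapiens) for inhibition, read by MTT assay, with a stated time of 48 h, tested at 10 uM; a higher number here means more inhibition at the concentration tested (going by the name of the read-out), a lower number less inhibition.
Compound 2, `Cc1cc(F)cc(Nc2cc(NC(=O)Nc3c(Cl)cccc3Cl)ncn2)c1`, gives 80%.
Compound 3, `COc1cc(NC(=O)Nc2cc(Nc3cccc(C(C)(C)C)c3)ncn2)cc(OC)c1`, gives 68%.

Compound 3 stands lowest of the three in this assay; compound 2 is nearest to it and compound 1 furthest, both above it by more than the scatter. The next compound, compound 4, `COc1cc(NC(=O)Nc2cc(Nc3ccc(Br)cc3OC)ncn2)cc(OC)c1`, differs from compound 3 in one place: 4-bromo-2-methoxyphenyl in place of 3-(tert-butyl)phenyl on a nitrogen on an aromatic ring. Going by the values given here, the only measured step that bears on this change is the swap of the aryl group on the same nitrogen, a number 12 percentage points lower from compound 1 to compound 2 (beyond the scatter), a modest shift. A comparable shift, in either direction, is therefore the most one can expect for compound 4. Compound 4 is expected to give about 62%, between 42% and 80%, a step of a number 6 percentage points lower from compound 3 to compound 4 (within the scatter) from compound 3.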

Compound 4, a percentage reported as inhibition, at one concentration (the size of the read-out at that concentration, not a potency): 83%
Compound 4: the middle estimate sits 21 percentage points below what was measured, outside the stated range (above it).
By their numbers in this assay, from the lowest: compound 3; then compounds 2, 4 and 1 (each within the scatter of the next, the first and the last beyond it).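

In this assay the aryl group on this nitrogen can also raise the number: the change gives a number 15 percentage points higher from compound 3 to compound 4 (beyond the scatter) and so runs opposite in direction to the earlier step, a number 12 percentage points lower from compound 1 to compound 2 (beyond the scatter), though that step has a different group on the other side of the molecule. The entering 4-bromo-2-methoxyphenyl brings oxygen, bromine and a hydrogen-bond acceptor at once, so this single step cannot separate them. No measurement at hand accounts for the rise. On these data alone, whether the methoxy or the bromine alone goes with it remains open, as does how an aryl group carrying an amine would fare on this nitrogen.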